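Trading a cyclohexylmethyl for a vinyl on the ester chain

The compounds below may be only part of what the source reports. "The series", "measured", "known", "first", "only" and "open" are said of these compounds alone.

Of the compounds shown here, three sharing one core have been tested in a functional assay on SK-BR-3 cells (Homo sapiens) for antiproliferative activity, read by MTT assay, with a stated time of 72 h; on this read-out lower numbers stand for stronger inhibition and higher numbers for weaker inhibition. Compound 1 `C/C=C1/[C@H](O[C@@H]2O[C@H](COC(C)=O)[C@@H](OC(C)=O)[C@H](OC(C)=O)[C@H]2OC(C)=O)OC=C(C(=O)O)[C@H]1CC(=O)O` is reported only as a limit of the assay, > 20000 nM. Compound 2 `C/C=C1/[C@H](O[C@@H]2O[C@H](CO)[C@@H](O)[C@H](O)[C@H]2O)OC=C(C(=O)OC)[C@H]1CC(=O)NCCC` is likewise reported only as a limit, > 20000 nM. Compound 3 `C/C=C1/[C@H](O[C@@H]2O[C@H](COC(C)=O)[C@@H](OC(C)=O)[C@H](OC(C)=O)[C@H]2OC(C)=O)OC=C(C(=O)OC)[C@H]1CC(=O)OCCC1CCCCC1` also reaches only a limit in this assay, > 15000 nM. Compound 3 thus stands among values that are all limits and no numbers: one value sits at the limit of > 15000 nM in this assay, at which 1 of the 3 values shown sits, and two values sit at the limit of > 20000 nM in this assay, at which 2 of the 3 values shown sit, so none of the three shows measurable inhibition of cell growth. No two of these compounds differ in only one place, so no single measured step can be read from them.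

The unmeasured compound 4 `C=CCOC(=O)C[C@@H]1C(C(=O)OC)=CO[C@@H](O[C@@H]2O[C@H](COC(C)=O)[C@@H](OC(C)=O)[C@H](OC(C)=O)[C@H]2OC(C)=O)/C1=C/C` arises from compound 3 by one change: vinyl in place of cyclohexylmethyl on a saturated chain carbon bound to an oxygen next to a carbonyl group. Among the compounds with values here, no measured step shows what a change of this kind does in this assay, and the three limits offer no sign of a compound crossing into measurable inhibition. The step from compound 3 is therefore expected to be a step that the limit leaves unreadable from compound 3 to compound 4, meaning no change beyond the usual scatter. Compound 4 is estimated at 30000 nM, within a range from 10000 nM to 100000 nM, and the assay is expected most likely to report only a limit again.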

Compound 4, half-maximal inhibitory concentration: > 20000 nM
Compound 4: a limit, no number; the forecaster's own chance of this, stated with the estimate: 85%; the middle value is on the limit's open side.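

No step can be read from compound 3 to compound 4: both are reported only as limits, not as numbers, in this assay. The compounds shown leave open whether any change to the ester chain, or elsewhere on the shared core, can bring measurable inhibition of cell growth.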